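The source may report more compounds than this note shows. Statements on the series, on what has been measured and on what is new or still open speak of the compounds shown alone.

Compound 1 `CC(C)c1ccc(NC(=O)N[C@H](C)c2ccccc2)cc1` gives 99% in an ADME assay on the whole organism with Oryza sativa as the target, tested at 0.1 uM; a lower number here means a stronger effect, a higher number a weaker effect of the compound at the concentration tested. Compound 2 `C[C@@H](NC(=O)Nc1ccc(C(C)(C)C)cc1)c1ccccc1` gives 100%. Compound 3 `C[C@H](NC(=O)Nc1ccc(C(C)(C)C)cc1)c1ccccc1` gives 100%.

Compound 2 stands level with compound 3, the two together the highest of the three numbers, with compound 1 lower only within the scatter. The two measured steps are small: a number 1 percentage points higher from compound 1 to compound 2 (within the scatter) and no change at the digits printed from compound 2 to compound 3 (within the scatter), the latter with the fact that compounds 2 and 3 differ only in the configuration as drawn. Compound 4 `CC(=O)c1ccc(NC(=O)N[C@H](C)c2ccccc2)cc1` has yet to be measured. Its change from compound 2 is acetyl in place of tert-butyl on an aromatic carbon. For the measured compounds named here, neither measured step touches the group on the aromatic carbon, so no measured step bears directly on this change. Compound 4 is therefore expected to stay near the top of the scale, with a step of a number 8 percentage points lower from compound 2 to compound 4 (within the scatter) and an estimate of 92%, ranging from 65% to 100%.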

Compound 4, a percentage reported as activity, at one concentration (the size of the read-out at that concentration, not a potency): 96%
Compound 4: the middle estimate sits 4 percentage points below what was measured, within the range that was stated.
By their numbers in this assay, from the lowest: compounds 4, 1, 2 and 3 (each within the scatter of the next).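

Compound 4 is the first compound shown to carry a group with oxygen and a hydrogen-bond acceptor on this aromatic carbon, where the earlier compounds held only the carbon groups isopropyl and tert-butyl. In this assay, this change gives a number 4 percentage points lower from compound 2 to compound 4 (within the scatter), and against the isopropyl group it gives a number 3 percentage points lower from compound 1 to compound 4 (within the scatter), so acetyl is not separated from either group. Nothing available bears on this result. As far as these compounds go, whether any group on this aromatic carbon can move the read-out beyond the scatter remains open. From the compounds shown here alone, what an amine, a carboxylic acid or a longer chain would give there also remains unknown.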